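This account rests on a few compounds, and the source may have more. Where it says the series, first, only, none or still open, it means among the compounds named here.

Measured compounds:
- compound 1, `COc1ccc(C2OC(c3cc(OC)c(OC)c(OC)c3)=NN2C(C)=O)c(OC)c1`: -3.1%
- compound 2, `COc1cc(C2=NN(C(C)=O)C(c3ccc(Cl)c(Cl)c3)O2)cc(OC)c1OC`: 3.1%
- compound 3, `COc1cc(C2=NN(C(C)=O)C(c3cccc(F)c3)O2)cc(OC)c1OC`: 37.7%

In a functional assay on BGC-823 cells (Homo sapiens) for antiproliferative activity, read by MTT assay, tested at 5 uM (on this read-out higher numbers stand for a stronger effect at the one concentration tested and lower numbers for a weaker effect), compound 3 holds the highest of the three numbers. Its lead is clear: the step of a number 40.8 percentage points higher from compound 1 to compound 3 (beyond the scatter) and the step of a number 34.6 percentage points higher from compound 2 to compound 3 (beyond the scatter) both lie beyond the scatter, whereas the step of a number 6.2 percentage points higher from compound 1 to compound 2 (within the scatter) stays within it, so compound 1 and compound 2 cannot be ordered against each other.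

Compound 4, `COc1cc(C2=NN(C(C)=O)C(c3ccc(F)c(F)c3)O2)cc(OC)c1OC`, is not yet measured. It differs from compound 3 by the change (fluoro in place of hydrogen on an aromatic carbon).

Going by the values given here, no measured step adds a single fluoro to an aryl group on a saturated ring carbon, so the expectation rests on indirect evidence. The two large steps into compound 3 show that the 3-fluorophenyl group is far ahead of the 3,4-dichlorophenyl group of compound 2, which carries two halogens on the same two positions that the 3,4-difluorophenyl group of compound 4 occupies. That comparison points toward some loss, but how much a second fluoro costs, if anything, is not fixed by these three compounds. The writer therefore expects a step of a number 12.7 percentage points lower from compound 3 to compound 4 (beyond the scatter) in this assay, a moderate decrease, with wide uncertainty. For compound 4 the estimated value in this assay is 25%, in a range from 0% to 50%.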

Compound 4, a percentage reported as inhibition, at one concentration (the size of the read-out at that concentration, not a potency): 21.6%
The estimate for compound 4 lay 3.4 percentage points above the measured number; the range from low to high includes it.
By their numbers in this assay, from the lowest: compounds 1 and 2 (each within the scatter of the next); then compound 4; then compound 3.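

In this assay, going by these compounds alone, the step to a number a number 16.1 percentage points lower from compound 3 to compound 4 (beyond the scatter) is the first to isolate a single fluoro in place of hydrogen on an aromatic carbon, ortho to a fluoro group and para to a large group. It shows that this position responds to even this one-atom change, as going from 3-fluorophenyl to 3,4-difluorophenyl costs part of the effect without removing it. The two halogens of the 3,4-disubstituted groups also prove not to be interchangeable, since 3,4-difluorophenyl in place of 3,4-dichlorophenyl gives a number 18.5 percentage points higher from compound 2 to compound 4 (beyond the scatter), while 3,4-difluorophenyl in place of 2,4-dimethoxyphenyl gives a number 24.7 percentage points higher from compound 1 to compound 4 (beyond the scatter), and nothing available explains any of these steps.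

From the compounds shown here alone, whether the fall follows from the added fluoro alone or from the pair of fluoro groups together remains open, as does how a methoxy group, an amine or a carboxylic acid would read at this same place on the ring. Going by these compounds, because each number reflects a single concentration, the compounds' potencies also remain open.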